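This account rests on a few compounds, and the source may have more. Where it says the series, first, only, none or still open, it means among the compounds named here.

Measured so far:
- Compound 1 `CCc1oc2ccc(OC)cc2c1C(=O)c1ccc(O)cc1` gives 2460 nM in an assay for inhibition of solute carrier family 22 member 12 (Homo sapiens), read by scintillation counting, with a stated time of 60 min; on this read-out higher numbers stand for weaker inhibition and lower numbers for stronger inhibition.
- Compound 2 `CCc1oc2ccc(O)cc2c1C(=O)c1ccc(O)cc1` gives 2490 nM in this assay.
- Compound 3 `CCc1oc2cc(O)ccc2c1C(=O)c1ccc(OC)cc1` has no reported result in this assay; its entry reads "not determined" (no result reported).

Compound 1 and compound 2 share one core and differ in a single spot: hydrogen in place of methyl on an oxygen on an aromatic ring. This change gave a 1.0-fold higher number from compound 1 to compound 2 (0.01 log units; within the scatter), so on this read-out the two compounds behave alike.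

Compound 3 is built from the same atoms as compound 1, joined differently; the difference between the two cores is not broken down here. Compound 4 `CCc1oc2cc(O)ccc2c1C(=O)c1ccc(O)cc1` is not yet measured. It stands to compound 3 exactly as compound 2 stands to compound 1: hydrogen in place of methyl on an oxygen on an aromatic ring. The place where the change sits is described in the same words for both pairs, so this is the same change made on a different core.

With no value for compound 3, the expectation for compound 4 can rest only on what compound 1 and compound 2 show: two compounds of this series that carry either methoxy or hydroxy at this position, on a related core, and sit at about the same level, since the step from one to the other is within the scatter. The corresponding step from compound 3 to compound 4 is therefore expected to be small as well. On that basis compound 4 is expected to give about 2500 nM in this assay, with a plausible range from 700 nM to 9000 nM. Among the compounds with values here, the range is wide because the only anchors are compound 1 with 2460 nM and compound 2 with 2490 nM, and the shift of the core is not quantified.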

Compound 4, half-maximal inhibitory concentration: 1130 nM
The estimate for compound 4 lay 2.2-fold (0.34 log units) above the measured number; the range from low to high includes it.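

Compound 3 carries no number in this assay, so the methoxy to hydroxy step from compound 3 to compound 4 cannot be read. From the compounds shown here alone, what stays open is whether this change on the core of compound 4 is as small as on the core of compound 1, where it gave a 1.0-fold higher number from compound 1 to compound 2 (0.01 log units; within the scatter). No further evidence bears on the value of compound 4.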